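The source may report more compounds than this note shows. Statements on the series, on what has been measured and on what is new or still open speak of the compounds shown alone.

Measured so far, in a functional assay on A549 cells (Homo sapiens) for antiproliferative activity, read by MTT assay, with a stated time of 72 h; on this read-out higher numbers stand for weaker inhibition and lower numbers for stronger inhibition:

compound 1 `COc1cc(N(C)CCN(C)C)c(NC(=O)c2cccnc2)cc1Nc1nccc(-c2cn(C)c3ccccc23)n1` — 1600 nM
compound 2 `COc1cc(N(C)CCN(C)C)c(NC(=O)c2ccncn2)cc1Nc1nccc(-c2cn(C)c3ccccc23)n1` — 2530 nM

Compound 2 stands at the higher of the two numbers, but the gap to compound 1 is small: a 1.6-fold higher number from compound 1 to compound 2 (0.20 log units; within the scatter), a step that changes only the heteroaryl on the carbonyl carbon and stays within the scatter.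

Compound 3 `COc1cc(N(C)CCN(C)C)c(NC(=O)c2ccncn2)cc1Nc1nccc(-c2cn(CCCO)c3ccccc23)n1` keeps the whole of compound 2 and changes one thing on the indole nitrogen substituent: 2-hydroxyethyl in place of hydrogen on a saturated chain carbon bound to an aromatic nitrogen. The entering group brings one hydrogen-bond donor and one acceptor on a short chain.

Among the compounds with values here, no measured step touches this position; the only step in hand concerns the amide heteroaryl, so it does not bear on the change from compound 2 to compound 3. With nothing to set a direction, the working expectation is a step of about a 1.0-fold lower number from compound 2 to compound 3 (0.01 log units; within the scatter), not beyond the scatter. Compound 3 is therefore estimated at 2500 nM, with a range of 1000 nM to 6500 nM in this assay.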

Compound 3, half-maximal inhibitory concentration: 2660 nM
Compound 3: the middle estimate sits 1.1-fold (0.03 log units) below what was measured; the measured number falls inside the stated range.
By their numbers in this assay, from the lowest: compounds 1, 2 and 3 (each within the scatter of the next).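

Within the data shown here, this is the first reading at the place on a saturated chain carbon bound to an aromatic nitrogen. In this assay, 2-hydroxyethyl in place of hydrogen, which reads as methyl to 3-hydroxypropyl when cut one bond further out, gives a 1.1-fold higher number from compound 2 to compound 3 (0.02 log units; within the scatter), so the series takes this added chain here without a step beyond the scatter. No measurement in hand accounts for this result.

From the compounds shown here alone, whether the position stays as flat with a terminal amine, a carboxylic acid or a longer chain in place of 3-hydroxypropyl remains open. Compounds 1, 2 and 3 all lie within the scatter of their neighbours, so they do not show what change at either varied place would produce a step beyond it.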